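The compounds below may be only part of what the source reports. "The series", "measured", "known", "first", "only" and "open" are said of these compounds alone.

Measured so far:
compound 1 `N#CSc1c(-c2ccccc2)nc2sc(Cc3ccccc3)nn12`: 75900 nM
compound 2 `O=Cc1c(-c2ccc([N+](=O)[O-])cc2)nc2sc(Cc3ccccc3)nn12`: 26300 nM

Both numbers come from a functional assay on cells (Cancer cell lines, Homo sapiens) for inhibition; on this read-out lower numbers stand for stronger inhibition of growth and higher numbers for weaker inhibition of growth. Compound 2 stands lowest of the two, and compound 1 sits well above it, a gap beyond the scatter; the two structures differ in more than one place, so nothing further is taken from that pair.

The next compound, compound 3 `O=[N+]([O-])c1ccc(-c2nc3sc(Cc4ccccc4)nn3c2Br)cc1`, keeps the rest of compound 2 and changes one position: bromo in place of formyl on an aromatic carbon. Within the data shown here, no measured pair in this set isolates a swap of this kind, so there is no step from which its size can be read. Going by these compounds, with the remainder of the molecule held, a single exchange of this sort is expected to move this assay little in either direction, most likely staying within the scatter of the number for compound 2; the swap is untested here, so the range is kept wide. Compound 3 is accordingly estimated at 30000 nM (range 8000 nM to 100000 nM). This amounts to an expected step of a 1.1-fold higher number from compound 2 to compound 3 (0.06 log units; within the scatter), that is, no change beyond the scatter is anticipated.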

Compound 3, concentration for total growth inhibition: 79400 nM
Estimate against measurement, compound 3: 2.6-fold (0.42 log units) below; the measured number falls inside the stated range.
By their numbers in this assay, from the lowest: compound 2; then compounds 1 and 3 (each within the scatter of the next).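

Among these compounds, on the aromatic carbon of the five-membered ring, the exchange of formyl for bromo gives the only single-place comparison so far: in this assay, the change produces a 3.0-fold higher number from compound 2 to compound 3 (0.48 log units; beyond the scatter). This step is modest but beyond the scatter, so this carbon is not indifferent to the group it carries, and with the rest of the molecule held, formyl gives stronger inhibition of growth than bromo. Nothing measured here bears on why the number moves with this exchange.

Among the compounds shown here, the single step cannot separate what is lost with the formyl, including its carbonyl and its hydrogen-bond acceptor, from what is gained with the bromo, and compound 1 differs from both compound 2 and compound 3 in more than one place, so it adds no reading on this carbon. Also open, going by these compounds, is how a carboxylic acid, an aminomethyl group or plain hydrogen on this carbon would stand against formyl and bromo, and whether the same exchange would give a step of similar size with the other parts of the molecule changed.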